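Compound 4 against the limit in the amino series

The source may hold more compounds than are shown below. What is called first, only, known or untested is meant among the compounds shown, and "the series" means these compounds.

Measured in a functional assay on ML1 cells (Homo sapiens) for antiproliferative activity, read by WST assay, with a stated time of 3 days; a higher number here means a weaker inhibitor, a lower number a stronger inhibitor:
- compound 1 `O=c1cc(I)n([C@@H]2O[C@H](CO)[C@@H](O)[C@H]2O)c(=O)[nH]1`: 15300 nM
- compound 2 `CNc1cc(=O)[nH]c(=O)n1[C@@H]1O[C@H](CO)[C@@H](O)[C@H]1O`: > 50000 nM (a limit)
- compound 3 `CN(C)c1cc(=O)[nH]c(=O)n1[C@@H]1O[C@H](CO)[C@@H](O)[C@H]1O`: > 50000 nM (a limit)

Compound 3 stands at the limit of > 50000 nM in this assay, at which 2 of the 3 values shown sit. Compound 4 `O=c1cc(NO)n([C@@H]2O[C@H](CO)[C@@H](O)[C@H]2O)c(=O)[nH]1` carries hydroxyamino in place of dimethylamino on an aromatic carbon. Among the measured compounds shown here, no measured step covers hydroxyamino directly. For the measured compounds named here, two steps bear on it, each putting methylamino or dimethylamino in place of iodo: an at least 3.2-fold higher number from compound 1 to compound 2 (0.51 log units; beyond the scatter), and an at least 3.2-fold higher number from compound 1 to compound 3 (0.51 log units; beyond the scatter). The third, a step that the two limits leave unreadable from compound 2 to compound 3, adds nothing on size. Hydroxyamino is expected to behave like these two groups, so only a small change is expected in this assay, with a weak result near the limit. The expected step is an at least 1.1-fold lower number from compound 3 to compound 4 (0.04 log units; that floor lies within the scatter). For compound 4 the estimate is 45000 nM, with an expected range of 15000 nM to 120000 nM.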

Compound 4, half-maximal inhibitory concentration: > 50000 nM
Compound 4: no number, only a limit (the forecaster's own chance of this, stated with the estimate: 60%); at least 1.1-fold (0.04 log units) between middle value and limit.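

In this assay compound 4 gives > 50000 nM, which is a limit. Hydroxyamino in place of iodo gives an at least 3.2-fold higher number from compound 1 to compound 4 (0.51 log units; beyond the scatter), so a nitrogen-linked group carrying oxygen fares no better here than methylamino or dimethylamino. The steps among compound 2, compound 3 and compound 4 cannot be read, and the three groups stay unranked at one shared limit: the limit of > 50000 nM in this assay, at which 3 of the 4 values shown sit.

From the compounds shown here alone, whether any group other than iodo on this aromatic carbon gives a number remains open. Chloro, bromo or plain amino would test whether a halogen is needed for a measurable value.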